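A few compounds are considered here, and "the series" means these few. Any claim that something is new, unique, unknown or untested is made for them only; others in the source may bear on it.

Two compounds share one core and differ only in the group on a saturated chain carbon two bonds along the chain from an amide-type nitrogen and a carbonyl carbon. Compound 1 `CC(C)C[C@H](NC(=O)CN(c1nc(Cl)nc2[nH]cnc12)C1CC1)C(=O)OCc1ccccc1` carries an isopropyl there, and in a functional assay on the whole organism (Tail, strain ICR) with Mus musculus as the target, in the tail flick test, with a stated time of 30 min, at a dose of 25 umol/kg by the oral route (a higher number here means a stronger effect of the compound at the dose given, a lower number a weaker effect), compound 1 gives 33.9%. Compound 2 `O=C(CN(c1nc(Cl)nc2[nH]cnc12)C1CC1)N[C@@H](CCC(=O)OCc1ccccc1)C(=O)OCc1ccccc1` carries a (benzyloxycarbonyl)methyl in that place, and in this assay compound 2 gives 52.8%. Among the measured compounds shown here, the single measured step, a number 18.9 percentage points higher from compound 1 to compound 2 (beyond the scatter), lies beyond the scatter, and compound 2 stands highest of the two numbers, with compound 1 the nearest.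

Compound 3 `O=C(CN(c1nc(Cl)nc2[nH]cnc12)C1CC1)N[C@@H](CO)C(=O)OCc1ccccc1` has not yet been measured. It differs from compound 2 in one place: hydroxy in place of (benzyloxycarbonyl)methyl on a saturated chain carbon, two bonds along the chain from an amide-type nitrogen and a carbonyl carbon. For the measured compounds named here, the only step that bears on this is a number 18.9 percentage points higher from compound 1 to compound 2 (beyond the scatter), in which the (benzyloxycarbonyl)methyl entered and the number rose modestly. In compound 3 that same group leaves again, while the hydroxy that enters has no measured counterpart among these compounds. A modest fall is therefore expected, roughly the earlier rise reversed, so the step of a number 18.8 percentage points lower from compound 2 to compound 3 (beyond the scatter) is expected in this assay. Compound 3 is estimated at 34%, within 14% to 54%.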

Compound 3, a percentage reported as activity, at one dose (the size of the read-out at that dose, not a potency): 31.9%
Compound 3: the middle estimate sits 2.1 percentage points above what was measured; the measured number falls inside the stated range.
By their numbers in this assay, from the lowest: compounds 3 and 1 (each within the scatter of the next); then compound 2.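

Putting hydroxy in place of (benzyloxycarbonyl)methyl on this saturated chain carbon gives a number 20.9 percentage points lower from compound 2 to compound 3 (beyond the scatter) in this assay, so the higher number does not come with just any replacement of the isopropyl. Hydroxy and isopropyl share one structural position but are very different groups, yet the step between them is a number 2 percentage points lower from compound 1 to compound 3 (within the scatter); among the three groups shown here, only the (benzyloxycarbonyl)methyl separates from the other two beyond the scatter. No supporting measurement is available to give a cause for these numbers.

The (benzyloxycarbonyl)methyl leaves as a whole, so these compounds leave open which of its parts goes with the higher number: the six-membered aromatic ring, the ester carbonyl or the length of the chain that carries them. A free carboxylic acid on the same chain, a plain benzyl group on this carbon or a longer chain ending in an amine would help separate those parts.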